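Three inactive amides and an untested methoxyphenyl analogue

The compounds below may be only part of what the source reports. "The series", "measured", "known", "first", "only" and "open" are said of these compounds alone.

The series shares one core, shown for compound 1 as `C=CC1=C(C(=O)Nc2ccccc2)C(c2ccc(Cl)c(Cl)c2)OC1`, with the amide nitrogen carrying the varied group. In a functional assay on QGY7701 cells (Homo sapiens) for cytotoxicity, read by MTT assay, with a stated time of 24 h (on this read-out lower numbers stand for stronger inhibition and higher numbers for weaker inhibition), compound 1 gives > 100000 nM, which is a limit of the assay and not a number. Compound 3, `C=CC1=C(C(=O)NCc2ccccc2)C(c2ccc(Cl)c(Cl)c2)OC1`, gives > 100000 nM in this assay, again a limit. The step that the two limits leave unreadable from compound 1 to compound 3 therefore cannot be sized. Compound 2, `C=CC1=C(C(=O)NCc2ccc(Cl)cc2)C(c2ccc(OC)cc2)OC1`, gives > 100000 nM in this assay, also a limit; compound 2 thus stands nowhere on a scale of numbers, only at the common ceiling, as the limit of > 100000 nM in this assay, at which 3 of the 3 values shown sit, records.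

Compound 4, `C=CC1=C(C(=O)Nc2ccccc2OC)C(c2ccc(OC)cc2)OC1`, differs from compound 2 by 2-methoxyphenyl in place of 4-chlorobenzyl on an amide-type nitrogen. For the measured compounds named here, no measured step bears directly on this change: the only step in the set, from compound 1 to compound 3, is unreadable, and every value sits at the limit. The expectation for compound 4 is accordingly that it too sits at or near the limit, with the step that the limit leaves unreadable from compound 2 to compound 4 expected to be none beyond the scatter. Compound 4 is estimated at 150000 nM in this assay, within a range of 40000 nM to 600000 nM, most likely reported only as a limit.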

Compound 4, half-maximal inhibitory concentration: > 100000 nM
Compound 4 gave a limit, no number (the forecaster's own chance of this, stated with the estimate: 85%); the middle value does not contradict the limit.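

Compound 4 gives > 100000 nM in this assay, a limit and not a number, so the change from compound 2 to compound 4 cannot be sized. All the compounds now share one ceiling: the limit of > 100000 nM in this assay, at which 4 of the 4 values shown sit.

The compounds shown leave open whether any group on the amide-type nitrogen changes the read-out at all.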